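Methyl for hydrogen in two anilino-pyrimidine and benzimidazole series

The source may hold more compounds than are shown below. What is called first, only, known or untested is meant among the compounds shown, and "the series" means these compounds.

Measured compounds:
compound 1 `O=[N+]([O-])c1cccc(Nc2nc3ncccc3n2Cc2ccccc2)c1` – 24200 nM
compound 2 `Cc1ccc(Nc2nc3ncccc3n2Cc2ccccc2)cc1[N+](=O)[O-]` – 27800 nM
compound 3 `NS(=O)(=O)c1cccc(Nc2nccc(-n3ncc4cccnc43)n2)c1` – 6930 nM

All three were tested in a functional assay on MCF7 cells (Homo sapiens) for antiproliferative activity, read by MTT assay, with a stated time of 72 h; on this read-out lower numbers stand for stronger inhibition of growth and higher numbers for weaker inhibition of growth. Compound 1 gives 24200 nM and compound 2 gives 27800 nM; the two differ by methyl in place of hydrogen on an aromatic carbon, and the step is a 1.1-fold higher number from compound 1 to compound 2 (0.06 log units; within the scatter). Compound 3 gives 6930 nM, the lowest of the three numbers, and its gap to compound 1 and to compound 2 is beyond the scatter. How the core of compound 3 differs from the core of compound 1 is not broken down here.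

Compound 4 `Cc1nn(-c2ccnc(Nc3cccc(S(N)(=O)=O)c3)n2)c2ncccc12` is not yet measured. It differs from compound 3 by methyl in place of hydrogen on an aromatic carbon, the same kind of change as from compound 1 to compound 2, but the place is not the same: in the earlier pair the methyl enters on a six-membered aromatic ring of carbon only, ortho to a nitro group and para to a large group, whereas here it enters on a five-membered aromatic ring with two nitrogen atoms, next to the ring nitrogen. Going by the values given here, because the only measured step of this kind, a 1.1-fold higher number from compound 1 to compound 2 (0.06 log units; within the scatter), lies within the scatter, compound 4 is expected to give a step of a 1.1-fold higher number from compound 3 to compound 4 (0.03 log units; within the scatter) in this assay. The estimate for compound 4 is 7500 nM, in the range 3000 nM to 18000 nM.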

Compound 4, concentration for 50% growth inhibition: 20000 nM
Compound 4: middle estimate off by 2.7-fold (0.43 log units), on the low side; measured number outside the range, above it.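

In this assay, methyl in place of hydrogen on an aromatic carbon of a five-membered aromatic ring with 2 nitrogen gives a 2.9-fold higher number from compound 3 to compound 4 (0.46 log units; beyond the scatter). Set beside the earlier step, this one does not differ from it by more than the scatter of two such steps: the same change on two cores in this assay, a 1.1-fold higher number (0.06 log units; within the scatter) from compound 1 to compound 2 and a 2.9-fold higher number (0.46 log units; beyond the scatter) from compound 3 to compound 4, 2.5-fold (0.40 log units) apart, within the scatter of two such steps The change therefore shows no measurable dependence on the core, yet two pairs do not show that it carries over unchanged, since only the step to compound 4 lies beyond the scatter, and the methyl sits in a different place in each pair, so the effects of core and place cannot be separated.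

The compounds shown leave open whether ethyl, an amine or a chlorine atom on the same aromatic carbon of compound 3 would move the number as methyl does. They also leave open what a methyl elsewhere on compound 3 would give, which would help separate place from core.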